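This account rests on a few compounds, and the source may have more. Where it says the series, first, only, none or still open, it means among the compounds named here.

Measured compounds:
Compound 1 `NC(=O)c1c(NC(=O)c2ccccc2Br)sc2c1CCN(C(=S)Nc1ccccc1Cl)C2` gives 12900 nM in a functional assay on MKN-74 cells (Homo sapiens) for antiproliferative activity, with a stated time of 24 h; on this read-out higher numbers stand for weaker inhibition and lower numbers for stronger inhibition.
Compound 2 `NC(=O)c1c(NC(=O)c2ccccc2C(F)(F)F)sc2c1CCN(C(=S)Nc1ccccc1Cl)C2` gives 21900 nM in this assay.
Compound 3 `NC(=O)c1c(NC(=O)c2ccccc2I)sc2c1CCN(C(=S)Nc1ccccc1Br)C2` gives 22400 nM in this assay.

Compound 4 `NC(=O)c1c(NC(=O)c2ccccc2I)sc2c1CCN(C(=S)Nc1ccccc1C(F)(F)F)C2` is not yet measured. The change from compound 1 to compound 2 is trifluoromethyl in place of bromo on an aromatic carbon and made a step of a 1.7-fold higher number from compound 1 to compound 2 (0.23 log units; within the scatter). The change from compound 3 to compound 4 is trifluoromethyl in place of bromo on an aromatic carbon, the same change at the same kind of place. The difference between the cores of compound 1 and compound 3 is not broken down here. As the first step stayed within the scatter, the step from compound 3 to compound 4 is expected to be small as well, estimated at a 1.3-fold higher number from compound 3 to compound 4 (0.13 log units; within the scatter), resting on the step from compound 1 to compound 2 and on the value of compound 3. Compound 4 is therefore expected at 30000 nM, between 12000 nM and 75000 nM.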

Compound 4, half-maximal inhibitory concentration: 14200 nM
The estimate for compound 4 lay 2.1-fold (0.32 log units) above the measured number, and the stated range covers the measured number.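

Trifluoromethyl in place of bromo on an aromatic carbon gives a 1.6-fold lower number from compound 3 to compound 4 (0.20 log units; within the scatter) in this assay. Set beside the earlier step, the same change does not carry over unchanged from one core to the other, and the two steps differ: the same change on two cores in this assay, a 1.7-fold higher number (0.23 log units; within the scatter) from compound 1 to compound 2 and a 1.6-fold lower number (0.20 log units; within the scatter) from compound 3 to compound 4, 2.7-fold (0.43 log units) apart, beyond the scatter of two such steps. With a single pair on each core, this does not show which feature of the cores separates the two steps, nor which way the change would go on a further core.

The aryl groups shown carry only halogen or trifluoromethyl, so the effect of an amine or a carboxylic acid at these places remains open. Also open, as far as these compounds go, is a nitrile in place of the carboxamide.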